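Methoxy for fluoro on a fused benzimidazole-type core

A few compounds are considered here, and "the series" means these few. Any claim that something is new, unique, unknown or untested is made for them only; others in the source may bear on it.

Compound 1 `O=C(O)CN1C(=O)/C(=C/c2nc3cc(F)ccc3n2Cc2ccccc2F)SC1=S` gives a limit of the assay in a functional assay on HL-60 cells (Homo sapiens) for cytotoxicity, read by MTT assay, with a stated time of 48 h; a higher number here means a weaker inhibitor, a lower number a stronger inhibitor: > 50000 nM.
Compound 2 `O=C(O)CN1C(=O)/C(=C/c2nc3ccc(F)cc3n2Cc2ccccc2F)SC1=S` gives 5230 nM in this assay.
Compound 3 `COc1ccc2c(c1)nc(/C=C1\SC(=S)N(CC(=O)O)C1=O)n2Cc1ccccc1F` gives 3410 nM in this assay.

The cores of compound 1 and compound 2 are built from the same atoms joined differently; the difference between the two cores is not broken down here. Compound 2 stands highest of the two numbers, with compound 3 nearest, within the scatter. From compound 1 to compound 3 the change is methoxy in place of fluoro on an aromatic carbon, and it made an at least 14-fold lower number from compound 1 to compound 3 (1.16 log units; beyond the scatter). Compound 4 `COc1ccc2nc(/C=C3\SC(=S)N(CC(=O)O)C3=O)n(Cc3ccccc3F)c2c1` is not yet measured; it differs from compound 2 by methoxy in place of fluoro on an aromatic carbon, the same change at the same place. He expects the step here to be smaller than the one from compound 1 to compound 3, because compound 2 already gives 5230 nM rather than a limit. The step he estimates is a 2.9-fold lower number from compound 2 to compound 4 (0.46 log units; beyond the scatter). His estimate for compound 4 in this assay is 1800 nM, between 500 nM and 6000 nM.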

Compound 4, half-maximal inhibitory concentration: 6440 nM
Estimate against measurement, compound 4: 3.6-fold (0.55 log units) below; the whole stated range lies below it.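

In this assay, methoxy in place of fluoro gave a 1.2-fold higher number from compound 2 to compound 4 (0.09 log units; within the scatter), so the change did not carry over in size from one core to the other: the same change on two cores in this assay, an at least 14-fold lower number (1.16 log units; beyond the scatter) from compound 1 to compound 3 and a 1.2-fold higher number (0.09 log units; within the scatter) from compound 2 to compound 4, at least 18-fold (1.25 log units) apart, beyond the scatter of two such steps. From the compounds shown here alone, compound 1 gives > 50000 nM, which is a limit of the assay and not a number, so the full size of the earlier step stays unknown: the limit of > 50000 nM in this assay, at which 1 of the 4 values shown sits. The two cores show that this step can differ from one core to another, but they do not show why it differs or how it would fall on a further core.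

The compounds shown leave open whether a chloro, hydroxyl or amine group in this place would separate the two cores in the same way. They also leave open whether a longer chain than methoxy would do so.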